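The source may report more compounds than this note shows. Statements on the series, on what has been measured and on what is new or still open speak of the compounds shown alone.

Among the compounds with values here, compound 1 `CCCS(=O)(=O)Nc1ccc(F)c(C(=O)Nc2cnc3[nH]ncc3c2)c1F` is the only compound here with a numerical reading. In a physicochemical assay for solubility, read by HPLC, in phosphate buffer, with a stated time of 24 h, at pH 6.5 (a higher number here means a more soluble compound, a lower number a less soluble compound), compound 1 gives 80 ug/mL. Compound 2 `CCCS(=O)(=O)Nc1ccc(F)c(C(=O)Nc2cnc3[nH]cc(Br)c3c2)c1F` is recorded in this assay only as a limit of the method, < 1 ug/mL. Compound 3 `CCCS(=O)(=O)Nc1ccc(F)c(C(=O)Nc2cnc3[nH]nc(Br)c3c2)c1F` has not yet been measured; it differs from compound 1 by bromo in place of hydrogen on an aromatic carbon. Within the data shown here, no measured pair isolates exactly this change, so the size of the step is uncertain. Because compound 2, which also carries a bromo, sits at the limit of < 1 ug/mL in this assay, at which 1 of the 2 values shown sits, a clear fall in solubility is expected, a 16-fold lower number from compound 1 to compound 3 (1.20 log units; beyond the scatter). For compound 3 the expected value is 5 ug/mL, estimated to lie between 1 ug/mL and 25 ug/mL.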

Compound 3, solubility: 1 ug/mL
The estimate for compound 3 lay 5.0-fold (0.70 log units) above the measured number; low and high end bracket the measured number.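

Placing a bromo on the five-membered aromatic ring with 2 nitrogen gives the first direct reading of this change in this assay: an 80-fold lower number from compound 1 to compound 3 (1.90 log units; beyond the scatter). A single heavy atom at this position is therefore enough for a large step. Compound 2, which also carries a bromo, is recorded only as a limit, not a number: the limit of < 1 ug/mL in this assay, at which 1 of the 3 values shown sits.

On these data alone, whether the fall belongs to bromo itself or to any group on this carbon remains open. A methyl, a fluoro or an amine here would help to separate the two.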